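A Pyrazole for a Phenyl on a Short-Lived Amide

The source may hold more compounds than are shown below. What is called first, only, known or untested is meant among the compounds shown, and "the series" means these compounds.

Measured so far in an ADME assay on microsomes (Rattus norvegicus) for metabolic stability; a lower number here means that the compound disappears faster, a higher number that the compound lasts longer
Compound 1 `O=C(c1ccccc1)N1CCC(C(=O)N2N=CCC2c2ccccc2)CC1` gives 0.0833 h
Compound 2 `Cc1ccc(C2CC=NN2C(=O)C(C)(C)C)cc1F` gives 0.0433 h
Compound 3 `CC(C)(C)C(=O)N1N=CCC1c1ccccn1` gives 1.32 h

The gap between compound 1 and compound 2 lies within the usual scatter of repeated measurements, so these two cannot be told apart. Compound 3 lasts clearly longer than either, and compound 1 stands far from it. Compound 4 `O=C(c1cn[nH]c1)N1CCC(C(=O)N2N=CCC2c2ccccc2)CC1` keeps the rest of compound 1 and changes one group: 1H-pyrazol-4-yl in place of phenyl on a carbonyl carbon. For the measured compounds named here, no measured pair here shows this swap, so this assay offers no direct guide, and any forecast is uncertain. Compound 3 differs from compound 1 in more than one place, so it shows only that a much longer half-life is possible among these compounds. The expected change is a modest rise, a 1.9-fold higher number from compound 1 to compound 4 (0.28 log units; within the scatter), close to the scatter rather than clearly beyond it. The expected value for compound 4 is 0.16 h, with 0.06 h to 0.5 h as its estimated range.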

Compound 4, half-life: > 2.75 h
Compound 4: a limit, no number (the forecaster's own chance of this, stated with the estimate: 3%); middle value at least 17-fold (1.23 log units) away from the limit.
By their numbers in this assay, from the lowest: compounds 2 and 1 (each within the scatter of the next); then compound 3. At a limit, above all of these: compound 4.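

In this assay the group on this carbonyl carbon turns out to matter a great deal: 1H-pyrazol-4-yl in place of phenyl gives an at least 33-fold higher number from compound 1 to compound 4 (1.51 log units; beyond the scatter) and lies far beyond the scatter. For the compounds shown here, until now no pair showed what a single change could do here, and this one shows that the rest of compound 1 does not tie these compounds to a short half-life, since changing this ring alone lifts it. The value of compound 4 is a limit, not a number: the limit of > 2.75 h in this assay, at which 1 of the 4 values shown sits.

The new ring differs from phenyl in ring size, in its two nitrogens and in its hydrogen-bond donor all at once, and this single pair does not separate these. The compounds shown also leave open how a thiophene ring, or a phenyl carrying an amine, would fare on this carbonyl carbon.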